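A few compounds are considered here, and "the series" means these few. Any claim that something is new, unique, unknown or untested is made for them only; others in the source may bear on it.

Measured compounds:
compound 1, `Cc1nc(-c2ccccc2)sc1CN1C(=O)N(C)c2ccc(-c3c(C)noc3C)cc2C1c1ccccc1`, giving 35.1%
compound 2, `Cc1noc(C)c1-c1ccc2c(c1)C(c1ccccc1)N(Cc1nc(-c3ccc(F)cc3)cs1)C(=O)N2C`, giving 27.4%

Both compounds were tested in a functional assay on MCF7 cells (Homo sapiens) for inhibition, read by MTT assay, with a stated time of 48 h, tested at 2 uM; on this read-out lower numbers stand for less inhibition and higher numbers for more inhibition at the one concentration tested (going by the name of the read-out). Compound 1 stands with the higher of the two numbers, and compound 2 sits close to it: the step of a number 7.7 percentage points lower from compound 1 to compound 2 (within the scatter) is within the scatter, so the two cannot be told apart on these numbers.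

Compound 3, `Cc1noc(C)c1-c1ccc2c(c1)C(c1ccccc1)N(Cc1csc(-c3ccc(F)cc3)n1)C(=O)N2C`, has not yet been measured. It differs from compound 1 in one place: 2-(4-fluorophenyl)-1,3-thiazol-4-yl in place of 4-methyl-2-phenyl-1,3-thiazol-5-yl on a saturated chain carbon bound to an amide-type nitrogen in a ring. Among the measured compounds shown here, the only measured step that bears on this is the one from compound 1 to compound 2, where the same leaving group was exchanged for a related group carrying a fluorophenyl ring on a thiazole, and that step stayed within the scatter. Compound 3 carries the same two rings as compound 2, joined at different points. For the measured compounds named here, with only one related step to go by, and that step small, no change beyond the scatter is expected in this assay for compound 3, and the expected step of a number 5.1 percentage points lower from compound 1 to compound 3 (within the scatter) is estimated to be small. Compound 3 is therefore expected to give about 30%, with a likely range from 15% to 45%.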

Compound 3, a percentage reported as inhibition, at one concentration (the size of the read-out at that concentration, not a potency): 37.9%
For compound 3 the middle estimate is 7.9 percentage points below the measured one; measured number inside the range.
By their numbers in this assay, from the lowest: compounds 2, 1 and 3 (each within the scatter of the next, the first and the last beyond it).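

In this assay, moving from the 4-(4-fluorophenyl)-1,3-thiazol-2-yl group to the 2-(4-fluorophenyl)-1,3-thiazol-4-yl group gives a number 10.5 percentage points higher from compound 2 to compound 3 (beyond the scatter), so at this position, on a saturated chain carbon bound to an amide-type nitrogen in a ring, the same two rings joined at different points can give a modest but readable difference. The other new comparison, a number 2.8 percentage points higher from compound 1 to compound 3 (within the scatter), shows that the 2-(4-fluorophenyl)-1,3-thiazol-4-yl group cannot be told apart from the 4-methyl-2-phenyl-1,3-thiazol-5-yl group on these numbers, so compound 1 lies within the scatter of both fluorinated compounds. Nothing available here accounts for the difference between compound 2 and compound 3.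

The compounds shown leave open what the plain 2-phenyl-1,3-thiazol-4-yl group would give, which would separate any contribution of the fluorine from that of the ring joining. They also leave open whether the thiazole can give way to another ring at this position, such as an oxazole or a pyridine, and how any of these compounds would behave at other concentrations in this assay.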